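From compound 1 to its chloro analogue, compound 4

A few compounds are considered here, and "the series" means these few. Any claim that something is new, unique, unknown or untested is made for them only; others in the source may bear on it.

Measured in a functional assay on K562 cells (Homo sapiens) for cytotoxicity, read by MTT assay, with a stated time of 48 h; a higher number here means a weaker inhibitor, a lower number a stronger inhibitor:
Compound 1 `COc1cc([C@@H]2C[C@@]2(CO)C(=O)Nc2ccccc2)cc(OC)c1OC`: > 100000 nM (a limit)
Compound 2 `CCOC(=O)C1(C(=O)Nc2ccc(OC)cc2)CC1c1cc(OC)c(OC)c(OC)c1`: > 100000 nM; > 100000 nM (2 entries) (a limit)
Compound 3 `COc1cc([C@H]2C[C@@]2(CO)C(=O)Nc2ccccc2)cc(OC)c1OC`: > 100000 nM (a limit)

Compound 1 stands with no number, only the limit > 100000 nM. Compound 4 `COc1cc([C@@H]2C[C@@]2(CO)C(=O)Nc2ccccc2Cl)cc(OC)c1OC` carries chloro in place of hydrogen on an aromatic carbon, ortho to a large group: chloro in place of hydrogen on an aromatic carbon. Among the measured compounds shown here, the only measured step is a step that the two limits leave unreadable from compound 1 to compound 3, and it concerns (the fact that compounds 1 and 3 differ only in the configuration as drawn). No measured step involves chloro, so nothing shown points to a gain in this assay. The expected result is no step beyond the scatter, written as a number no higher from compound 1 to compound 4 (the limit leaves the size open). For compound 4 the estimate is 100000 nM, with an expected range of 30000 nM to 200000 nM.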

Compound 4, half-maximal inhibitory concentration: 18400 nM
Beside the measured number, compound 4's estimate is 5.4-fold (0.74 log units) above it; measured number outside the range, below it.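

In this assay, chloro in place of hydrogen on an aromatic carbon, ortho to a large group, gives an at least 5.4-fold lower number from compound 1 to compound 4 (0.73 log units; beyond the scatter). Among the compounds shown here, this shows that a single change at this position of the phenyl can bring a compound of this kind to a measurable number, which the earlier compounds did not show. The true size of the step stays unknown, since it starts from a limit: the limit of > 100000 nM in this assay, at which 2 of the 4 values shown sit.

Going by these compounds, it remains open whether fluoro, methyl or a nitrile at this position would give a similar step. Also open, on these data alone, is whether chloro would act alike in the configuration of compound 3.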